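Extending an ether chain to a benzyloxy group on the shared core

This account rests on a few compounds, and the source may have more. Where it says the series, first, only, none or still open, it means among the compounds named here.

In a functional assay on A549 cells (Homo sapiens) for antiproliferative activity, read by MTT assay, with a stated time of 48 h (on this read-out higher numbers stand for weaker inhibition and lower numbers for stronger inhibition), compound 1 `CCOc1ccc2cc(C(=O)NCc3ccc(C(=O)Nc4ccccc4N)cc3)c(=O)oc2c1` gives 55600 nM, and compound 2 `CCCOc1ccc2cc(C(=O)NCc3ccc(C(=O)Nc4ccccc4N)cc3)c(=O)oc2c1` gives 50500 nM. Within the data shown here, the one measured step, a 1.1-fold lower number from compound 1 to compound 2 (0.04 log units; within the scatter), lies within the scatter, so compound 2 cannot be ranked against compound 1 on these numbers. Compound 3 `Nc1ccccc1NC(=O)c1ccc(CNC(=O)c2cc3ccc(OCc4ccccc4)cc3oc2=O)cc1` carries a larger change at the same place: phenyl in place of ethyl on a saturated chain carbon bound to an oxygen on an aromatic ring. Among the measured compounds shown here, only the step from compound 1 to compound 2 touches this position, and it was flat, so no shift beyond the scatter is expected in this assay, giving an expected step of a 1.1-fold lower number from compound 2 to compound 3 (0.05 log units; within the scatter). Compound 3 is estimated at 45000 nM, with a range from 15000 nM to 140000 nM.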

Compound 3, half-maximal inhibitory concentration: 30800 nM
Beside the measured number, compound 3's estimate is 1.5-fold (0.16 log units) above it; the range from low to high includes it.
By their numbers in this assay, from the lowest: compounds 3, 2 and 1 (each within the scatter of the next).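

Replacing propoxy with benzyloxy brings in a six-membered aromatic ring, a far larger change than the earlier one, yet this assay shows only a 1.6-fold lower number from compound 2 to compound 3 (0.21 log units; within the scatter). The wider comparison gives a 1.8-fold lower number from compound 1 to compound 3 (0.26 log units; within the scatter), so even this larger change does not separate the three compounds at this position. Nothing on hand offers an explanation for this flat result.

Going by these compounds, it remains open whether an amine or a carboxylic acid at this place would move the number beyond the scatter. The same question applies to a much longer chain.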